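The source may hold more compounds than are shown below. What is called first, only, known or untested is meant among the compounds shown, and "the series" means these compounds.

Working notes on the series. In an assay on isolated protein (Bos taurus) for inhibition of geranylgeranyl transferase type-1 subunit beta (Homo sapiens) (on this read-out higher numbers stand for weaker inhibition and lower numbers for stronger inhibition), compound 1 `Cn1cncc1C(OCc1ccc(C#N)nc1-c1ccc2ccccc2c1)c1ccc(C#N)cc1` gives 5500 nM. Compound 2 `Cn1cncc1C(OCc1ccc(C#N)nc1-c1ccccc1)c1ccc(C#N)cc1` sits at a limit of the assay, and in this assay compound 2 gives > 10 nM, a limit rather than a number. The step that the limit leaves unreadable from compound 1 to compound 2 therefore cannot be read, as the limit of > 10 nM in this assay, at which 1 of the 2 values shown sits, shows. Compound 3 `Cn1cncc1C(OCc1ccc(C#N)nc1-c1cccc(Cl)c1)c1ccc(C#N)cc1` differs from compound 2 by chloro in place of hydrogen on an aromatic carbon. Within the data shown here, no measured step bears readably on this change, so the expected step that the limit leaves unreadable from compound 2 to compound 3 in this assay is set at none beyond the scatter. For compound 3 the estimate in this assay is 60 nM, within 10 nM to 1500 nM.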

Compound 3, half-maximal inhibitory concentration: 1700 nM
The estimate for compound 3 lay 28-fold (1.45 log units) below the measured number; the whole stated range lies below it.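

In this assay, among these compounds, 3-chlorophenyl in place of naphthalen-2-yl on an aromatic carbon gives a 3.2-fold lower number from compound 1 to compound 3 (0.51 log units; beyond the scatter), the first readable step at this position. The group on this aromatic carbon can therefore change the number, although this one step shows only a modest change. The step from compound 2 to compound 3 cannot be read, and the effect of chloro on phenyl remains unsized: the limit of > 10 nM in this assay, at which 1 of the 3 values shown sits.

Whether chloro itself accounts for any of the step remains open. Also open, on these data alone, is how a methoxy group or an amine on the same phenyl ring would compare with chloro.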